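The source may hold more compounds than are shown below. What is called first, only, known or untested is meant among the compounds shown, and "the series" means these compounds.

Compound 1 `FC(F)(F)c1ccc(CSc2nc(Nc3ccccc3)c3ccccc3n2)cc1` gives 18400 nM in a functional assay on MDA-MB-231 cells (Homo sapiens) for cytotoxicity, read by MTT assay, with a stated time of 72 h; a lower number here means a stronger inhibitor, a higher number a weaker inhibitor. Compound 2 `FC(F)(F)c1ccc(CSc2nc(Nc3ccc(Cl)cc3)c3ccccc3n2)cc1` gives 15100 nM. Compound 3 `FC(F)(F)c1ccc(CSc2nc(Nc3ccc(C(F)(F)F)cc3)c3ccccc3n2)cc1` gives 5460 nM.

Compound 3 has the lowest number of the three: it is ahead of compound 2 by a 2.8-fold lower number from compound 2 to compound 3 (0.44 log units; beyond the scatter) and of compound 1 by a 3.4-fold lower number from compound 1 to compound 3 (0.53 log units; beyond the scatter), both beyond the scatter. Compound 4 `COc1cc(Nc2nc(SCc3ccc(C(F)(F)F)cc3)nc3ccccc23)cc(OC)c1` differs from compound 3 by 3,5-dimethoxyphenyl in place of 4-(trifluoromethyl)phenyl on a nitrogen on an aromatic ring. Among the compounds with values here, the steps that bear on this change are a 3.4-fold lower number from compound 1 to compound 3 (0.53 log units; beyond the scatter) and a 2.8-fold lower number from compound 2 to compound 3 (0.44 log units; beyond the scatter), which show that the trifluoromethyl brought a modest gain, while a 1.2-fold lower number from compound 1 to compound 2 (0.09 log units; within the scatter) stayed within the scatter. Within the data shown here, no measured compound carries a methoxy group, so the 3,5-dimethoxyphenyl group is untested. Compound 4 gives up the trifluoromethyl, so the expected step is a 2.2-fold higher number from compound 3 to compound 4 (0.34 log units; beyond the scatter), toward a higher number, with wide uncertainty. Compound 4 is estimated at 12000 nM, between 4000 nM and 40000 nM.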

Compound 4, half-maximal inhibitory concentration: 16100 nM
Estimate against measurement, compound 4: 1.3-fold (0.13 log units) below; measured number inside the range.
By their numbers in this assay, from the lowest: compound 3; then compounds 2, 4 and 1 (each within the scatter of the next).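

Replacing 4-(trifluoromethyl)phenyl with 3,5-dimethoxyphenyl on this nitrogen gives back the advantage of compound 3 (a 2.9-fold higher number from compound 3 to compound 4 (0.47 log units; beyond the scatter)). The 3,5-dimethoxyphenyl group shows no difference beyond the scatter from 4-chlorophenyl (a 1.1-fold higher number from compound 2 to compound 4 (0.03 log units; within the scatter)) or from plain phenyl (a 1.1-fold lower number from compound 1 to compound 4 (0.06 log units; within the scatter)), so among these four compounds only the 4-(trifluoromethyl)phenyl group stands apart. No measurement here explains these differences. Open, going by these compounds, is how an amine or a carboxylic acid on this phenyl ring would compare, and whether a longer chain could replace the ring.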